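Trading an isopropylcarbonyl ester for a free hydroxyl

The source may hold more compounds than are shown below. What is called first, only, known or untested is meant among the compounds shown, and "the series" means these compounds.

Of the compounds shown here, three sharing one core have been tested in a functional assay on DLD-1 cells (Homo sapiens) for cytotoxicity, with a stated time of 48 h; a higher number here means a weaker inhibitor, a lower number a stronger inhibitor. Compound 1 `COc1cccc2c(=O)cc(/C=C/[S+](C)[O-])oc12` gives 9000 nM. Compound 2 `CC(C)C(=O)Oc1ccc2oc(/C=C/[S+](C)[O-])cc(=O)c2c1` gives 9100 nM. Compound 3 `Cc1cccc2oc(/C=C/[S+](C)[O-])cc(=O)c12` gives 5500 nM. Compound 2 sits at the upper end of these three numbers, yet compound 1 and compound 3 both fall within the usual scatter of it, so the three cannot be told apart on this evidence.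

The next compound, compound 4 `C[S+]([O-])/C=C/c1cc(=O)c2cc(O)ccc2o1`, has not yet been measured in this assay. It differs from compound 2 in one place: hydrogen in place of isopropylcarbonyl on an oxygen on an aromatic ring. In other words, the (isopropylcarbonyl)oxy group of compound 2 becomes a hydroxy group in compound 4.

Within the data shown here, no pair of measured compounds differing in a single place is available, so there is no measured step to lean on. Given that compound 1, compound 2 and compound 3 all cluster closely in this assay despite carrying different groups on the core, the expectation is that the step of a 1.1-fold higher number from compound 2 to compound 4 (0.04 log units; within the scatter) stays within or only slightly beyond the scatter. Compound 4 is therefore estimated to give about 10000 nM in this assay, with a likely range from 4000 nM to 25000 nM.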

Compound 4, half-maximal inhibitory concentration: > 10000 nM
Compound 4: no number, only a limit; the forecaster's own chance of this, stated with the estimate: 15%; the middle value sits exactly at the limit.
By their numbers in this assay, from the lowest: compounds 3, 1 and 2 (each within the scatter of the next). At a limit, above all of these: compound 4.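

In this assay, compound 4 gives > 10000 nM, and this value is a limit of the assay, not a number. Putting hydrogen in place of isopropylcarbonyl on this oxygen on an aromatic ring gives the only single-place step among these compounds, an at least 1.0-fold higher number from compound 2 to compound 4 (0.04 log units; that floor lies within the scatter), so the (isopropylcarbonyl)oxy group and the hydroxy group cannot be told apart on this floor alone. The change shows no sign of a gain in this assay, but its true size remains unknown, and the reading rests on a single value at the limit: the limit of > 10000 nM in this assay, at which 1 of the 4 values shown sits.

On these data alone, what other groups on this oxygen would do remains open, for example a smaller acetyl ester, a longer acyl chain or a simple methyl ether. As far as these compounds go, it is also open whether the step from the ester to the hydroxy group goes beyond the usual scatter, a question that only a full number for compound 4 could settle.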